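This account rests on a few compounds, and the source may have more. Where it says the series, first, only, none or still open, it means among the compounds named here.

Compound 1 `C=CC1=C(C(=O)Nc2ccccc2)C(c2ccc(OC)cc2)OC1` and compound 2 `C=CC1=C(C(=O)NCCCCC)C(c2ccc(OC)cc2)OC1` share one core and differ only at the amide nitrogen, where a pentyl takes the place of a phenyl. In a functional assay on QGY7701 cells (Homo sapiens) for cytotoxicity, read by MTT assay, with a stated time of 24 h (on this read-out lower numbers stand for stronger inhibition and higher numbers for weaker inhibition), compound 1 reaches only a limit, > 100000 nM. In this assay compound 2 likewise reaches only a limit, > 100000 nM. The step that the two limits leave unreadable from compound 1 to compound 2 therefore cannot be sized, because of the limit of > 100000 nM in this assay, at which 2 of the 2 values shown sit. Compound 3 `C=CC1=C(C(=O)NCCC)C(c2ccc(OC)cc2)OC1` shortens the chain further: hydrogen in place of ethyl on a saturated chain carbon, three bonds along the chain from an amide-type nitrogen, so the pentyl becomes a propyl. Within the data shown here, no measured step gives a readable size, and the nearest measured neighbour, compound 2, sits at a limit with > 100000 nM. The step that the limit leaves unreadable from compound 2 to compound 3 is therefore expected to stay within the usual scatter, with the outcome most likely once more a limit rather than a number. Compound 3 is estimated at 150000 nM, within 50000 nM to 500000 nM, in this assay.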

Compound 3, half-maximal inhibitory concentration: > 100000 nM
Compound 3: a limit, no number (the forecaster's own chance of this, stated with the estimate: 85%); the middle value is on the limit's open side.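

Among these compounds, compound 1, compound 2 and compound 3 all end at a limit in this assay, so no step among them can be read: the limit of > 100000 nM in this assay, at which 3 of the 3 values shown sit. The compounds shown leave open whether any group on the amide nitrogen would give a readable number in this assay.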